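The source may hold more compounds than are shown below. What is called first, only, known or untested is meant among the compounds shown, and "the series" means these compounds.

Compound 1, with structure `O=C(NCCNS(=O)(=O)c1ccc(-c2ccccc2Oc2ccc([N+](=O)[O-])c([N+](=O)[O-])c2)s1)Nc1cc(C(F)(F)F)cc(C(F)(F)F)c1`, was tested in a functional assay on HL-60 cells (Homo sapiens) for inhibition, read by CCK-8 assay, with a stated time of 48 h (a lower number here means a stronger inhibitor, a higher number a weaker inhibitor), where compound 1 gives 1900 nM. For the measured compounds named here, of the two values measured so far, this is the lowest. The other compound, compound 2, with structure `O=[N+]([O-])c1ccc(NC(=S)NCCNS(=O)(=O)c2ccc(-c3ccccc3O[C@H]3CC[C@H](O)CC3)s2)cc1`, gives 11600 nM in this assay, and the gap between the two lies beyond the usual scatter of repeated measurements. Compound 2 differs from compound 1 at several places at once, so no single structural change can be read off from that pair.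

The compound not yet measured is compound 3, with structure `Nc1ccc(Oc2ccccc2-c2ccc(S(=O)(=O)NCCNC(=O)Nc3cc(C(F)(F)F)cc(C(F)(F)F)c3)s2)cc1`. It differs from compound 1 in one place: 4-aminophenyl in place of 3,4-dinitrophenyl on an oxygen on an aromatic ring. Going by the values given here, no measured pair shows this change on its own, so the size and direction of the step have to be judged without a precedent. A modest weakening is expected, a 2.1-fold higher number from compound 1 to compound 3 (0.32 log units; beyond the scatter), though a step lying within the scatter would not be surprising. Compound 3 is therefore expected to give about 4000 nM in this assay, within a range from 1200 nM to 13000 nM.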

Compound 3, half-maximal inhibitory concentration: > 50000 nM
Compound 3 was reported as a limit (the forecaster's own chance of this, stated with the estimate: 5%); middle value at least 12-fold (1.09 log units) from the limit.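

Swapping 3,4-dinitrophenyl for 4-aminophenyl on the oxygen gives the only single-place step available here, and in this assay it is large: an at least 26-fold higher number from compound 1 to compound 3 (1.42 log units; beyond the scatter). This shows that the group at this position can decide whether the compound inhibits at measurable levels, which the pair of compound 1 and compound 2 could not show, as those two differ at several places at once. For compound 3 the reported value is a limit and not a number: the limit of > 50000 nM in this assay, at which 1 of the 3 values shown sits.

The swap also changes several things together, going from 12 heavy atoms to 7, from 0 hydrogen-bond donors to 1, and from 4 hydrogen-bond acceptors to 1, so this one step cannot say which of these counts, if any, matters. A 4-nitrophenyl or 3-nitrophenyl group would show whether one nitro group is enough, while a plain phenyl and a 4-acetamidophenyl group would help separate losing the nitro groups from gaining the free amine.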